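Trading 4-(2-formylethynyl)benzyl for allyl on the shared core

The compounds below may be only part of what the source reports. "The series", "measured", "known", "first", "only" and "open" are said of these compounds alone.

Compound 1 `CCc1c(C(F)c2cc(C)cc(C)c2)n(COCc2ccc(C#CC=O)cc2)c(=O)[nH]c1=O`: 27000 nM
Compound 2 `Cc1c(C(C)c2c(F)cccc2F)nc(N(C)C)[nH]c1=O`: >= 100000 nM (a limit)

Going by the values given here, in an ADME assay on MT4 cells (Homo sapiens) for cytotoxicity, read by MTT assay, with a stated time of 96 h (on this read-out higher numbers stand for lower toxicity in this test and lower numbers for higher toxicity in this test), compound 1 gives 27000 nM as the only true number available so far. Compound 2 stands at >= 100000 nM and this is a limit of the assay, not a number. Compound 1 therefore has no second number to be ranked against.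

The step followed here leads to compound 3 `C=CCOCn1c(C(F)c2cc(C)cc(C)c2)c(CC)c(=O)[nH]c1=O`, which keeps the core of compound 1. The change is vinyl in place of 4-(2-formylethynyl)phenyl on a saturated chain carbon bound to an oxygen on a saturated carbon. Among the compounds with values here, no measured pair shows what such a swap does in this assay, so the expectation rests on little. A moderate step toward lower toxicity in this test is expected, since compound 1 at 27000 nM still leaves room on this read-out. The limit seen for compound 2 lies further up. The estimated step is a 2.6-fold higher number from compound 1 to compound 3 (0.41 log units; beyond the scatter) and it may end at that limit. For compound 3 the expected value is 70000 nM, with an estimated range from 25000 nM to 130000 nM.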

Compound 3, half-maximal cytotoxic concentration: 64000 nM
Beside the measured number, compound 3's estimate is 1.1-fold (0.04 log units) above it, within the range that was stated.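

In this assay, going by these compounds alone, this pair gives the first measured step at this place, on a saturated chain carbon bound to an oxygen on a saturated carbon: vinyl in place of 4-(2-formylethynyl)phenyl gives a 2.4-fold higher number from compound 1 to compound 3 (0.37 log units; beyond the scatter), which points toward lower toxicity in this test. The change removes the aromatic ring, the triple bond and the formyl group together, yet compound 3 still gives a true number rather than a limit, so this single swap does not carry the shared core to the end of the read-out. Compound 2 stands at a limit of the assay and not at a number: the limit of >= 100000 nM in this assay, at which 1 of the 3 values shown sits.

The step cannot say which part of the departing group accounts for the difference, since the aromatic ring, the triple bond and the formyl group leave as one, and a plain phenyl at this place would be needed to begin separating them. It also leaves open how this assay would respond to an ethyl group, a longer saturated chain, an amine or a carboxylic acid in place of the vinyl group on the shared core.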